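The compounds below may be only part of what the source reports. "The series", "measured", "known", "first", "only" and "open" are said of these compounds alone.

In an ADME assay on MDCKII-LE cells (Canis lupus familiaris) for permeability, read by transwell migration, in the apical to basolateral direction (on this read-out lower numbers stand for lower permeability and higher numbers for higher permeability), compound 1 `NC(=O)[C@@H](CCC(F)(F)F)N(C[C@@H]1CCCCO1)S(=O)(=O)c1ccc(Cl)cc1` gives 15.4 10^-6 cm/s and compound 2 `NC(=O)[C@@H](CCC(F)(F)F)N(C[C@H]1COCCO1)S(=O)(=O)c1ccc(Cl)cc1` gives 20.6 10^-6 cm/s, so these two values stand within the scatter of each other. Compound 3 `NC(=O)[C@@H](CCC(F)(F)F)N(C[C@@H]1CCOC1)S(=O)(=O)c1ccc(Cl)cc1` is not yet measured and differs from compound 2 as follows: oxolan-3-yl in place of 1,4-dioxan-2-yl on a saturated chain carbon bound to a sulfonamide nitrogen. In words, oxolan-3-yl replaces 1,4-dioxan-2-yl on a saturated chain carbon bound to a sulfonamide nitrogen. Within the data shown here, the only measured step at this place is a 1.3-fold higher number from compound 1 to compound 2 (0.13 log units; within the scatter), within the scatter, so no step beyond the scatter is expected in this assay. Compound 3 is estimated at 18 10^-6 cm/s, with an expected range of 9 10^-6 cm/s to 34 10^-6 cm/s. The expected step is a 1.1-fold lower number from compound 2 to compound 3 (0.06 log units; within the scatter).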

Compound 3, apparent permeability: 20.5 10^-6 cm/s
Beside the measured number, compound 3's estimate is 1.1-fold (0.06 log units) below it; the measured number falls inside the stated range.
By their numbers in this assay, from the lowest: compounds 1, 3 and 2 (each within the scatter of the next).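

In this assay oxolan-3-yl gives a 1.0-fold lower number from compound 2 to compound 3 (0.00 log units; within the scatter) and a 1.3-fold higher number from compound 1 to compound 3 (0.12 log units; within the scatter) on a saturated chain carbon bound to a sulfonamide nitrogen. A five-membered non-aromatic ring thus stands within the scatter of the six-membered rings of compound 1 and compound 2, so ring size at this place has produced no step beyond the scatter so far.

On these data alone, whether an amine, a carboxylic acid or an open-chain ether at this place would give such a step remains open. No measurement at hand gives a cause for these numbers.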